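A few compounds are considered here, and "the series" means these few. Any claim that something is new, unique, unknown or untested is made for them only; others in the source may bear on it.

In a functional assay on C8166 cells (Homo sapiens) for antiproliferative activity, read by MTT assay (on this read-out lower numbers stand for higher toxicity in this test and higher numbers for lower toxicity in this test), compound 1 `Cc1cc(C)cc(S(=O)(=O)c2c(C(=O)NN3CCOC3=O)[nH]c3ccc(Cl)cc23)c1` gives > 100 uM, which is a limit of the assay and not a number. Compound 2 `CNNC(=O)c1[nH]c2ccc(Cl)cc2c1S(=O)(=O)c1cc(C)cc(C)c1` gives > 100 uM, also a limit. Compound 3 `Cc1cc(C)cc(S(=O)(=O)c2c(C(=O)NNC3CCCCC3)[nH]c3ccc(Cl)cc23)c1` gives > 100 uM, again a limit. All three compounds therefore share one position, (the limit of > 100 uM in this assay, at which 3 of the 3 values shown sit). Compound 4 `CCOC(=O)NNC(=O)c1[nH]c2ccc(Cl)cc2c1S(=O)(=O)c1cc(C)cc(C)c1` carries ethoxycarbonyl in place of cyclohexyl on an amine nitrogen. The closest measured change for compound 3 is a step that the two limits leave unreadable from compound 2 to compound 3, and the others are a step that the two limits leave unreadable from compound 1 to compound 3 and a step that the two limits leave unreadable from compound 1 to compound 2, so none offers a size to carry over. No step beyond the scatter, and no direction, is expected in this assay. The expected change is a number no higher from compound 3 to compound 4 (the limit leaves the size open). For compound 4 the estimated value is 100 uM, within an expected range of 40 uM to 200 uM.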

Compound 4, half-maximal toxic concentration: > 100 uM
Compound 4 gave a limit, no number; the forecaster's own chance of this, stated with the estimate: 80%; the middle value lies on the limit itself.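

For the compounds shown here, compound 4, like compound 1, compound 2 and compound 3, gives only a limit and not a number, so no step between them can be read: the limit of > 100 uM in this assay, at which 4 of the 4 values shown sit. As far as these compounds go, how toxic these compounds actually are, and whether the group on the amine nitrogen matters for that, stays open.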